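Compound 2 and Its Mirrored Stereocentre

A few compounds are considered here, and "the series" means these few. Any claim that something is new, unique, unknown or untested is made for them only; others in the source may bear on it.

In a functional assay on HCT-116 cells (Homo sapiens) for cytotoxicity, read by hypoxanthine incorporation, with a stated time of 72 h, tested at 10 uM (a lower number here means less inhibition of growth, a higher number more inhibition of growth at the concentration tested), compound 1 `CC(C)C[C@@H]1NC(=O)[C@H](CCCN/C(=N/C(=O)OCc2ccccc2)NC(=O)OCc2ccccc2)NC(=O)[C@H](C(C)C)NC(=O)[C@H](CC(C)C)NC(=O)[C@@H](Cc2ccc(O)cc2)NC1=O` gives 2% and compound 2 `CC(C)C[C@@H]1NC(=O)[C@@H]([C@H](OCc2ccccc2)c2ccccc2)NC(=O)[C@@H](Cc2ccccc2)NC(=O)[C@@H](CC(C)C)NC(=O)[C@H](C(C)C)N(C)C1=O` gives 94% at the single concentration tested. Among the measured compounds shown here, compound 2 therefore holds the higher of the only two numbers available, and the gap to compound 1 lies well beyond the usual scatter. These two compounds differ in many places, so their gap says nothing about a single change.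

Compound 3 `CC(C)C[C@@H]1NC(=O)[C@H]([C@H](OCc2ccccc2)c2ccccc2)NC(=O)[C@@H](Cc2ccccc2)NC(=O)[C@@H](CC(C)C)NC(=O)[C@H](C(C)C)N(C)C1=O` has not yet been measured. Its relation to compound 2 is simple: the two compounds have the same atoms and bonds and differ only in configuration as drawn: 1 of 6 stereo elements differ; a stereocentre at a saturated ring carbon is drawn R in compound 2 and S in compound 3 and nothing else separates them, since a stereocentre at a saturated ring carbon is drawn R in compound 2 and S in compound 3.

For the measured compounds named here, no measured pair here shows what one such inversion does, so any forecast is loose. Little room remains upward because compound 2 already gives 94% on this scale, and a downward move is the likelier direction. The expected change is a number 34 percentage points lower from compound 2 to compound 3 (beyond the scatter) in this assay as an estimated step that may exceed the scatter. For compound 3 the estimated value is 60% with an expected range of 15% to 98% in this assay once tested.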

Compound 3, percent growth inhibition at one concentration: 25%
Compound 3: middle estimate off by 35 percentage points, on the high side, within the range that was stated.
By their numbers in this assay, from the lowest: compound 1; then compound 3; then compound 2.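

In this assay, among the compounds shown here, the inversion of a stereocentre at a saturated ring carbon, drawn R in compound 2 and S in compound 3, comes with a number 69 percentage points lower from compound 2 to compound 3 (beyond the scatter), and this is the first reading of a single change in the set. The earlier comparison, compound 1 against compound 2, spanned many differences at once and could not tie any part of its gap to one place, whereas this pair shows that the drawn configuration at this one carbon can by itself carry a large part of the growth inhibition seen at the concentration tested. The drop can be assigned to that centre alone, because neither atoms nor bonds separate the two compounds: the fact that compounds 2 and 3 differ only in the configuration as drawn

The compounds shown leave open whether the same inversion would count for as much in a compound carrying an amine or a carboxylic acid at this position. On these data alone, each reading also comes from a single concentration on one cell line, so how the two mirrored forms compare across a range of concentrations or on other cells remains unknown.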